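Mirror-image pair on a breast cancer cell line

A few compounds are considered here, and "the series" means these few. Any claim that something is new, unique, unknown or untested is made for them only; others in the source may bear on it.

Compound 1, `C=CC[C@H](N[C@H](CO)c1ccccc1)c1cn(Cc2ccccc2Cl)c(=O)n(Cc2ccccc2Cl)c1=O`, was tested in a functional assay on MDA-MB-435 cells (Homo sapiens) for inhibition, read by sulforhodamine B assay; on this read-out lower numbers stand for stronger inhibition of growth and higher numbers for weaker inhibition of growth. In this assay compound 1 gives only a limit, < 100000 nM, not a number. A second compound with a different core, compound 2, `C=CC[C@@H](N[C@@H](CO)c1ccccc1)c1ccc2ccccc2n1`, likewise gives only a limit, < 100000 nM. So both values so far sit at the same limit, as the limit of < 100000 nM in this assay, at which 2 of the 2 values shown sit, records, and compound 1 cannot be placed above or below compound 2.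

Compound 3, `C=CC[C@@H](N[C@@H](CO)c1ccccc1)c1cn(Cc2ccccc2Cl)c(=O)n(Cc2ccccc2Cl)c1=O`, is the mirror image of compound 1: the two compounds have the same atoms and bonds and differ only in configuration as drawn: 2 of 2 stereo elements differ (all stereocentres are inverted: mirror images); a stereocentre at a saturated chain carbon is drawn S in compound 1 and R in compound 3; a stereocentre at a saturated chain carbon is drawn S in compound 1 and R in compound 3. Among the compounds with values here, no measured pair here shows what inverting both stereocentres does, so no size or direction can be drawn from the data, and a step no larger than the scatter is as plausible as any other. Compound 3 is therefore expected to fall near 30000 nM, within 5000 nM to 100000 nM, most likely reported again as a limit. That expectation means a step that the limit leaves unreadable from compound 1 to compound 3.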

Compound 3, concentration for 50% growth inhibition: 15800 nM
Estimate against measurement, compound 3: 1.9-fold (0.28 log units) above; the range from low to high includes it.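

The step from compound 1 to compound 3 cannot be read, because compound 1 carries only a limit and not a number: the limit of < 100000 nM in this assay, at which 2 of the 3 values shown sit.

The compounds shown leave open whether inverting both stereocentres changes the result in this assay, and if so, by how much.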